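The source may report more compounds than this note shows. Statements on the series, on what has been measured and on what is new or still open speak of the compounds shown alone.

So far, a functional assay on PC-3 cells (Homo sapiens) for antiproliferative activity, with a stated time of 48 h (on this read-out lower numbers stand for stronger inhibition and higher numbers for weaker inhibition), has given these results:

- Compound 1 `CCN(CC)c1ccc(-c2cccc(C(F)(F)F)c2)nn1` gives > 25000 nM as a limit
- Compound 2 `COc1ccccc1-c1ccc(N2CCN(C)CC2)nn1` gives > 25000 nM as a limit
- Compound 3 `CN1CCN(c2ccc(-c3cccc(C(F)(F)F)c3)nn2)CC1` gives > 25000 nM as a limit

Compound 3 stands at > 25000 nM and this is a limit, not a number. Going by the values given here, it is not alone there, for the series so far shows the limit of > 25000 nM in this assay, at which 3 of the 3 values shown sit, and no measured number. Compound 4 `FC(F)(F)c1cccc(-c2ccc(N3CCCC3)nn2)c1` carries pyrrolidin-1-yl in place of 4-methylpiperazin-1-yl on an aromatic carbon of the shared core, as pyrrolidin-1-yl in place of 4-methylpiperazin-1-yl on an aromatic carbon sets out. Among the compounds with values here, the only measured step at this place is a step that the two limits leave unreadable from compound 1 to compound 3 and it gives no size to carry over. With no readable step to go on and all three compounds held at the same limit, no change beyond the scatter is expected in this assay and no direction can be claimed, so the expected step is a number no higher from compound 3 to compound 4 (the limit leaves the size open) and no more than that. Compound 4 is estimated at 25000 nM with a range from 10000 nM to 50000 nM and is expected most likely to be reported only as a limit.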

Compound 4, half-maximal inhibitory concentration: > 25000 nM
Compound 4: only a limit was reported (the forecaster's own chance of this, stated with the estimate: 80%); the middle value lies on the limit itself.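

In this assay compound 4 gives > 25000 nM, which is a limit, so no step from compound 1 or compound 3 to compound 4 can be read: the limit of > 25000 nM in this assay, at which 4 of the 4 values shown sit.

The compounds shown leave open whether diethylamino, 4-methylpiperazin-1-yl and pyrrolidin-1-yl differ at all on this read-out.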